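The source may report more compounds than this note shows. Statements on the series, on what has been measured and on what is new or still open speak of the compounds shown alone.

Compound 3 `COc1cccc(CNc2ncnc3c2ncn3[C@@H]2O[C@H](CO)[C@@H](O)[C@H]2O)c1O` carries a 2-hydroxy-3-methoxyphenyl group on a saturated chain carbon bound to a nitrogen on an aromatic ring. In a functional assay on K562 cells (Homo sapiens) for antiproliferative activity, with a stated time of 72 h (on this read-out lower numbers stand for stronger inhibition and higher numbers for weaker inhibition), compound 3 gives 27900 nM, the lowest of the two numbers measured in the series. Compound 1 `OC[C@H]1O[C@@H](n2cnc3c(NCc4ccc(Cl)cc4)ncnc32)[C@H](O)[C@@H]1O`, with 4-chlorophenyl at the same place, gives 218000 nM in this assay; the change 2-hydroxy-3-methoxyphenyl in place of 4-chlorophenyl is a 7.8-fold lower number from compound 1 to compound 3 (0.89 log units; beyond the scatter). Compound 2 `COc1cccc(CNc2ncnc3c2ncn3[C@@H]2O[C@H](CO)[C@@H](O)[C@H]2O)c1OC`, with 2,3-dimethoxyphenyl, reports only a limit in this assay, > 166000 nM. The step that the limit leaves unreadable from compound 1 to compound 2 therefore cannot be sized, while an at least 5.9-fold lower number from compound 2 to compound 3 (0.77 log units; beyond the scatter) reads hydrogen in place of methyl on an oxygen on an aromatic ring.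

Compound 4 `OC[C@H]1O[C@@H](n2cnc3c(NCc4ccccc4OC(F)F)ncnc32)[C@H](O)[C@@H]1O` is not yet measured. It differs from compound 3 by 2-(difluoromethoxy)phenyl in place of 2-hydroxy-3-methoxyphenyl on a saturated chain carbon bound to a nitrogen on an aromatic ring. The two readable steps bear on it: the hydrogen-bond donor that compound 3 alone holds leaves, and the aryl group returns to a donor-free pattern shared with compound 1 and compound 2, both of which sit far above compound 3. For the measured compounds named here, a rise beyond the scatter is expected in this assay, in the direction of compound 1, though the difluoromethoxy group itself has no precedent. Compound 4 is estimated at 120000 nM, in the range 40000 nM to 300000 nM, meaning an expected step of a 4.3-fold higher number from compound 3 to compound 4 (0.63 log units; beyond the scatter).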

Compound 4, half-maximal inhibitory concentration: > 166000 nM
Compound 4: no number, only a limit; the forecaster's own chance of this, stated with the estimate: 30%; at least 1.3-fold (0.14 log units) between middle value and limit.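

In this assay, 2-(difluoromethoxy)phenyl in place of 2-hydroxy-3-methoxyphenyl on a saturated chain carbon bound to a nitrogen on an aromatic ring is an at least 5.9-fold higher number from compound 3 to compound 4 (0.77 log units; beyond the scatter). This extends the earlier reading from an at least 5.9-fold lower number from compound 2 to compound 3 (0.77 log units; beyond the scatter): a third aryl group without a hydrogen-bond donor now stands well away from compound 3, and none of the four compounds goes against this pattern. The steps to compound 4 from compound 1 and compound 2 cannot be read, so the three donor-free aryl groups cannot be ranked against one another: the limit of > 166000 nM in this assay, at which 2 of the 4 values shown sit.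

Open is whether the hydroxyl at this place needs the methoxy group of 2-hydroxy-3-methoxyphenyl, since a plain 2-hydroxyphenyl group does not stand among the compounds shown. For the compounds shown here, also open is whether an aminophenyl or carboxyphenyl group on the same saturated chain carbon would give a lower number than compound 3, at 27900 nM, which remains the only compound with a readable advantage.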